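Moving the hydroxyl on the cyclohexyl ring of compound 2

The source may report more compounds than this note shows. Statements on the series, on what has been measured and on what is new or still open speak of the compounds shown alone.

Measured so far:
Compound 1 `O=C(NCCCOc1ccc2nc(O)ccc2c1)N(C1CCCCC1)[C@H]1CCCC[C@@H]1O` gives 18% in a functional assay on the whole organism for inhibition, with Rattus norvegicus as the target, at a dose of 30 mg/kg by the oral route; a lower number here means less inhibition, a higher number more inhibition at the dose given (going by the name of the read-out).
Compound 2 `O=C(NCCCOc1ccc2nc(O)ccc2c1)N(C1CC1)[C@@H]1CCC[C@@H](O)C1` gives 0% in this assay.

For the measured compounds named here, compound 2 stands lowest of the two numbers measured so far, and its gap to compound 1 lies beyond the usual scatter. Going by the values given here, the two compounds differ in more than one place, so no single step between them can be drawn; their values show only that one gives inhibition and the other gives none.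

Compound 3 `O=C(NCCCOc1ccc2nc(O)ccc2c1)N(C1CC1)[C@H]1CCCC[C@@H]1O` is still to be measured. It differs from compound 2 in one place: 2-hydroxycyclohexyl in place of 3-hydroxycyclohexyl on an amide-type nitrogen. Compound 3 keeps the cyclopropyl group of compound 2 and takes the 2-hydroxycyclohexyl group of compound 1.

Among the compounds with values here, no measured step shows what this move alone does. Since compound 1, which carries the 2-hydroxycyclohexyl group, gives 18%, a small rise in this assay is expected for compound 3, as the step of a number 8 percentage points higher from compound 2 to compound 3 (within the scatter), though this may still sit within the scatter. Compound 3 is therefore estimated at 8%, within a range from 0% to 25%.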

Compound 3, a percentage reported as inhibition, in the whole organism at one dose (the size of the read-out at that dose, not a potency): 13%
Beside the measured number, compound 3's estimate is 5 percentage points below it; low and high end bracket the measured number.
By their numbers in this assay, from the lowest: compound 2; then compounds 3 and 1 (each within the scatter of the next).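

In this assay, placing 2-hydroxycyclohexyl instead of 3-hydroxycyclohexyl on the amide-type nitrogen gives a number 13 percentage points higher from compound 2 to compound 3 (beyond the scatter). The two groups have the same atoms and the same counts of donors and acceptors, so this step shows that the read-out responds to how this group is arranged, at least with cyclopropyl as the other group on that nitrogen. With 2-hydroxycyclohexyl held in place, cyclopropyl in place of cyclohexyl gives a number 5 percentage points lower from compound 1 to compound 3 (within the scatter), so this exchange cannot be told apart from the scatter, and nothing measured here gives a reason for either step.

The compounds shown leave open whether the hydroxyl is needed at all, which a plain cyclohexyl group or an amine or methoxy group at the same ring position could test. They also leave open whether the step from 3-hydroxycyclohexyl to 2-hydroxycyclohexyl would be the same with cyclohexyl as the other group on the nitrogen, and how far it depends on the arrangement of the two defined stereocentres.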